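From Naphthalen-1-yl to 4-Nitrobenzyl: Cytotoxicity Outlook

A few compounds are considered here, and "the series" means these few. Any claim that something is new, unique, unknown or untested is made for them only; others in the source may bear on it.

Measured compounds:
- compound 1, `C[C@H](NC(=O)[C@]1(Cc2ccccc2)CCN1C(=O)Oc1cccc2ccccc12)C(N)=O`: in an ADME assay on HELF cells (Homo sapiens) for cytotoxicity, with a stated time of 3 days (on this read-out higher numbers stand for lower toxicity in this test and lower numbers for higher toxicity in this test), compound 1 gives > 100000 nM, a limit of the assay rather than a number.
- compound 2, `CC(C)[C@H](NC(=O)[C@@]1(Cc2ccccc2)CCN1C(=O)OCc1ccccc1)C(N)=O`: in this assay compound 2 gives > 100000 nM, likewise a limit and not a number.

Compound 1 therefore stands at the edge of what this test can report: the limit of > 100000 nM in this assay, at which 2 of the 2 values shown sit. Going by the values given here, no step between measured compounds is available, since the two compounds differ in more than one place, and both values are limits, so nothing about size or direction of change can be read from them.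

The unmeasured compound 3, `C[C@H](NC(=O)[C@]1(Cc2ccccc2)CCN1C(=O)OCc1ccc([N+](=O)[O-])cc1)C(N)=O`, is reached from compound 1 by 4-nitrobenzyl in place of naphthalen-1-yl on an oxygen next to a carbonyl group. Among the compounds with values here, with no measured step to lean on, the expectation is that the change brings no shift beyond the usual scatter in this assay, and that compound 3 will most likely also be reported only as a limit. On that basis compound 3 is estimated at 100000 nM, within a range from 40000 nM to 250000 nM, which means an expected step of a number no higher from compound 1 to compound 3 (the limit leaves the size open).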

Compound 3, minimum cytotoxic concentration: 100000 nM
Compound 3: middle estimate and measured number agree at the digits printed, within the range that was stated.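

In this assay, 4-nitrobenzyl in place of naphthalen-1-yl on an oxygen next to a carbonyl group gives a number no higher from compound 1 to compound 3 (the limit leaves the size open), and the size of this step cannot be read. Compound 3 gives 100000 nM, and it is the only one of the three compounds shown with a plain number rather than a limit, so this position now has a read-out that the test reports as a value. That number still stands at the same figure as the limits, and the picture stays at the edge of what the test can report: the limit of > 100000 nM in this assay, at which 2 of the 3 values shown sit.

Whether compound 3 truly differs from compound 1 stays open, and no compound shown has a lower number that would reveal how far the read-out can move with a change at this position. The compounds shown also leave open how a chain ending in an amine or a carboxylic acid on an oxygen next to a carbonyl group would read in this assay, and whether the nitro group or the loss of one aromatic ring counts for more.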